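A few compounds are considered here, and "the series" means these few. Any claim that something is new, unique, unknown or untested is made for them only; others in the source may bear on it.

Measured in a toxicity assay on MCF-10A cells (Homo sapiens) for cytotoxicity, read by MTT assay, with a stated time of 48 h; on this read-out lower numbers stand for stronger inhibition and higher numbers for weaker inhibition:
compound 1 `O=C(/C=C/c1ccc2c(c1)B(O)OC2)c1ccccc1` gives 15900 nM
compound 2 `O=C(/C=C/c1ccc2c(c1)B(O)OC2)c1ccc(F)cc1` gives 11800 nM
compound 3 `O=C(/C=C/c1ccc2c(c1)B(O)OC2)c1ccc(O)cc1` gives 24800 nM

Compound 3 gives the highest number of the three; its gap to compound 1 lies within the scatter, while its gap to compound 2 is beyond it, a 2.1-fold higher number from compound 2 to compound 3 (0.32 log units; beyond the scatter). Compound 4 `O=C(/C=C/c1ccc2c(c1)B(O)OC2)c1cccc(O)c1` differs from compound 3 in one place: 3-hydroxyphenyl in place of 4-hydroxyphenyl on a carbonyl carbon. Among the compounds with values here, no measured step moves a group around the ring. The steps that involve hydroxy, a 1.6-fold higher number from compound 1 to compound 3 (0.19 log units; within the scatter) and a 2.1-fold higher number from compound 2 to compound 3 (0.32 log units; beyond the scatter), were small, and all three measured numbers sit in a narrow band. No step beyond the scatter is therefore expected in this assay for compound 4, in either direction. The expected step from compound 3 is a 1.1-fold lower number from compound 3 to compound 4 (0.05 log units; within the scatter). Compound 4 is estimated at 22000 nM, with a range from 10000 nM to 50000 nM.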

Compound 4, half-maximal inhibitory concentration: 25300 nM
Compound 4: the middle estimate sits 1.2-fold (0.06 log units) below what was measured; the measured number falls inside the stated range.
By their numbers in this assay, from the lowest: compounds 2, 1, 3 and 4 (each within the scatter of the next, the first and the last beyond it).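

In this assay, within the data shown here, 3-hydroxyphenyl in place of 4-hydroxyphenyl on the carbonyl carbon gives the first comparison of two placements of one group on this ring, and it separates nothing (a 1.0-fold higher number from compound 3 to compound 4 (0.01 log units; within the scatter)). The 3-hydroxyphenyl group also matches the earlier pattern for 4-hydroxyphenyl, staying within the scatter against phenyl (a 1.6-fold higher number from compound 1 to compound 4 (0.20 log units; within the scatter)) and going just beyond it against 4-fluorophenyl (a 2.1-fold higher number from compound 2 to compound 4 (0.33 log units; beyond the scatter)). No measured evidence here bears on these steps.

As far as these compounds go, whether an amine, a carboxylic acid or a methoxy group on this ring would leave the narrow band remains open.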